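The compounds below may be only part of what the source reports. "The series", "measured", "known", "first", "only" and "open" are said of these compounds alone.

Measured so far in a functional assay on PC-3 cells (Homo sapiens) for inhibition, read by MTT assay, with a stated time of 48 h; a higher number here means a weaker inhibitor, a lower number a stronger inhibitor:
compound 1 `COc1ccc(-n2c(SC)nnc2-c2cc(OC)c(OC)c(OC)c2)cc1`: > 60000 nM (a limit)
compound 2 `COc1ccc(-n2c(SCc3ccccc3)nnc2-c2cc(OC)c(OC)c(OC)c2)cc1`: 34100 nM
compound 3 `COc1ccc(-n2c(SCc3ccc(C)cc3)nnc2-c2cc(OC)c(OC)c(OC)c2)cc1`: 56500 nM

These compounds share a core and differ only on a saturated chain carbon bound to a sulfur. Compound 1 gives > 60000 nM, which is a limit of the assay and not a number. Compound 3 gives 56500 nM, and its nearest measured comparison is a 1.7-fold higher number from compound 2 to compound 3 (0.22 log units; within the scatter). On these data, compound 2 and compound 3 cannot be told apart.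

Compound 4 `COc1ccc(-n2c(SCC(=O)c3ccccc3)nnc2-c2cc(OC)c(OC)c(OC)c2)cc1` keeps the core and makes a single swap: benzoyl in place of 4-methylphenyl on a saturated chain carbon bound to a sulfur. In words, this is benzoyl in place of 4-methylphenyl on a saturated chain carbon bound to a sulfur.

For the measured compounds named here, no measured compound carries benzoyl, so the closest guides are indirect. They are an at least 1.7-fold lower number from compound 1 to compound 2 (0.24 log units; that floor lies within the scatter) and an at least 1.0-fold lower number from compound 1 to compound 3 (0.02 log units; that floor lies within the scatter), together with the methyl step between compound 2 and compound 3 already given. All of these stay within the scatter, so no step beyond the scatter is expected in this assay. The expected change is a 1.4-fold lower number from compound 3 to compound 4 (0.15 log units; within the scatter), a small drift towards compound 2 at 34100 nM. For compound 4 the estimated value is 40000 nM, with an expected range from 15000 nM to 60000 nM.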

Compound 4, half-maximal inhibitory concentration: > 60000 nM
Compound 4 gave a limit, no number (the forecaster's own chance of this, stated with the estimate: 25%); middle value at least 1.5-fold (0.17 log units) from the limit.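

In this assay compound 4 gives a limit and not a number, the second such entry among these compounds: the limit of > 60000 nM in this assay, at which 2 of the 4 values shown sit.

Benzoyl, which brings a carbonyl that 4-methylphenyl and phenyl lack, gives an at least 1.0-fold higher number from compound 3 to compound 4 (0.02 log units; that floor lies within the scatter) and an at least 1.7-fold higher number from compound 2 to compound 4 (0.24 log units; that floor lies within the scatter); both floors lie within the scatter, so these data do not separate compound 4 from compound 2 or compound 3. The step from compound 1 to compound 4 cannot be read, since both ends are limits, and among the steps that can be read, none on this saturated chain carbon bound to a sulfur goes beyond the scatter, now including one with a carbonyl-bearing group.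

Still open, on these data alone, is whether an amine, a carboxylic acid or a longer chain on this carbon would produce a step beyond the scatter. Whether the carbonyl itself has any effect would need a direct comparison of benzoyl with benzyl on the same carbon.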